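The source may hold more compounds than are shown below. What is called first, only, known or untested is meant among the compounds shown, and "the series" means these compounds.

For the measured compounds named here, compound 1 `CC#C[C@@H](Cc1nnn[nH]1)c1ccc(OCc2ccc3scc(-c4cccnc4C)c3c2)cc1` is one of two compounds measured in a functional assay on cells for agonist activity at Free fatty acid receptor 1 (Homo sapiens), read by FLIPR and calcium flux; on this read-out lower numbers stand for an effect already at smaller amounts and higher numbers for an effect only at larger amounts of compound. In this assay compound 1 gives 88 nM. Going by the values given here, the only other number belongs to compound 2 `CC#C[C@@H](Cc1nnn[nH]1)c1ccc(OCc2ccc3scc(-c4ccc(OCCCS(C)(=O)=O)cc4C)c3c2)cc1`, which carries a substituted phenyl in place of the pyridine of compound 1; in this assay compound 2 gives 12 nM. Of the two numbers, compound 1 thus stands at the higher one, and the gap to compound 2 lies beyond the usual scatter.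

The step from compound 1 to compound 3 `CC#C[C@@H](Cc1nnn[nH]1)c1ccc(OCc2ccc3scc(C4CCCCC4)c3c2)cc1` changes only the substituent on the shared core: cyclohexyl in place of 2-methylpyridin-3-yl on an aromatic carbon. Among the compounds with values here, with the two measured compounds both carrying an aromatic ring at that position, there is no directly comparable step to draw on, so the expectation rests on the spread already seen. Compound 3 is expected to be close to compound 1 or somewhat less active, with a step estimated at a 1.7-fold higher number from compound 1 to compound 3 (0.23 log units; within the scatter). For compound 3 the estimated value in this assay is 150 nM, with a range from 40 nM to 600 nM.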

Compound 3, half-maximal effective concentration: 107 nM
Beside the measured number, compound 3's estimate is 1.4-fold (0.15 log units) above it; the range from low to high includes it.
By their numbers in this assay, from the lowest: compound 2; then compounds 1 and 3 (each within the scatter of the next).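

In this assay the exchange of 2-methylpyridin-3-yl for cyclohexyl gives a 1.2-fold higher number from compound 1 to compound 3 (0.08 log units; within the scatter) and so leaves the two compounds indistinguishable on this read-out. The earlier compounds shown here both carried an aromatic ring on this aromatic carbon, two ring bonds from the ring sulfur, whereas compound 3 shows that a non-aromatic ring of carbon only, with no hydrogen-bond acceptor, reads within the scatter of a six-membered aromatic ring with one hetero atom and one hydrogen-bond acceptor. Nothing available here bears on why these two substituents read alike.

The compounds shown leave open whether a smaller group at this place, such as methyl, an open chain such as n-butyl, or a cyclohexyl bearing an amine or a carboxylic acid would keep the number near compound 3 at 107 nM or bring it toward compound 2 at 12 nM on this read-out. They also leave open whether the propyl chain ending in a methyl sulfone, which compound 2 carries on its phenyl, would give a similar number when attached to the cyclohexyl of compound 3.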